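This account rests on a few compounds, and the source may have more. Where it says the series, first, only, none or still open, it means among the compounds named here.

Three compounds have been measured so far in an ADME assay for permeability, using PAMPA, at pH 7.4 (a higher number here means that the compound crosses the layer faster, a lower number that the compound crosses the layer more slowly), as follows:

compound 1 `CC(=O)c1ccc(NC(=O)Nc2cc(C)nc3ccccc23)cc1` gives 473 10^-6 cm/s
compound 2 `Cc1cc(NC(=O)Nc2cccc([N+](=O)[O-])c2)c2ccccc2n1` gives 42 10^-6 cm/s
compound 3 `COc1ccc(NC(=O)Nc2cc(C)nc3ccccc23)cc1F` gives 50 10^-6 cm/s

Compound 1 stands highest of the three, and compound 2 and compound 3 both lie below it by more than the scatter. Compound 4 `Cc1cc(NC(=O)Nc2ccc(OC(F)(F)F)cc2)c2ccccc2n1` is still unmeasured. It has trifluoromethoxy in place of acetyl on an aromatic carbon, para to a large group trifluoromethoxy in place of acetyl on an aromatic carbon and shares the rest of its structure with compound 1. For the measured compounds named here, no measured pair differs in one place only, so the guide here is loose. With compound 2 at 42 10^-6 cm/s and compound 3 at 50 10^-6 cm/s as the only other points, a fall beyond the scatter is expected in this assay for this change. The expected move is a 3.9-fold lower number from compound 1 to compound 4 (0.60 log units; beyond the scatter) and it remains only an estimate. Compound 4 is estimated at 120 10^-6 cm/s with a range from 30 10^-6 cm/s to 480 10^-6 cm/s for now.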

Compound 4, apparent permeability: 531 10^-6 cm/s
The estimate for compound 4 lay 4.4-fold (0.65 log units) below the measured number, and the stated range ends below it.
By their numbers in this assay, from the lowest: compounds 2 and 3 (each within the scatter of the next); then compounds 1 and 4 (each within the scatter of the next).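

Trifluoromethoxy in place of acetyl on an aromatic carbon, para to a large group, gives readings that cannot be told apart in this assay, with a 1.1-fold higher number from compound 1 to compound 4 (0.05 log units; within the scatter) as the step. For the compounds shown here, this is the first comparison of two compounds that differ in one place only. It shows that, on this shared core, acetyl is not needed at this position for a number at the level of compound 1.

Going by these compounds, whether an amine, a carboxylic acid or a longer chain at this position would also match compound 1 remains open. Nothing measured on these compounds gives a reason for the match.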